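Swapping the Ring on a Sulfonamide Nitrogen

This account rests on a few compounds, and the source may have more. Where it says the series, first, only, none or still open, it means among the compounds named here.

Measured so far in a functional assay on BT-549 cells (Homo sapiens) for inhibition, read by sulforhodamine B assay, with a stated time of 48 h; a lower number here means a stronger inhibitor of growth, a higher number a weaker inhibitor of growth:
compound 1 `C=C1CC[C@@H]2[C@](C)(COC(C)=O)[C@H](OC(C)=O)CC[C@@]2(C)[C@H]1CC(Nc1ccc(S(=O)(=O)Nc2nccs2)cc1)C1=CCOC1=O` gives 6500 nM
compound 2 `C=C1CC[C@@H]2[C@](C)(COC(C)=O)[C@H](OC(C)=O)CC[C@@]2(C)[C@H]1CC(Nc1ccc(S(=O)(=O)Nc2ccc(Cl)nn2)cc1)C1=CCOC1=O` gives 3140 nM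

Among the compounds with values here, compound 2 holds the lower of these two numbers; the single known step, a 2.1-fold lower number from compound 1 to compound 2 (0.32 log units; beyond the scatter), separates it from compound 1. Compound 3 `C=C1CC[C@@H]2[C@](C)(COC(C)=O)[C@H](OC(C)=O)CC[C@@]2(C)[C@H]1CC(Nc1ccc(S(=O)(=O)Nc2ncccn2)cc1)C1=CCOC1=O` is not yet measured and differs from compound 2 by pyrimidin-2-yl in place of 6-chloropyridazin-3-yl on a sulfonamide nitrogen. Within the data shown here, the only step bearing on this change is a 2.1-fold lower number from compound 1 to compound 2 (0.32 log units; beyond the scatter), a modest shift from a ring swap on the same sulfonamide nitrogen, so in this assay a step of about that size, or none beyond the scatter, is expected, more likely towards a higher number. Compound 3 is therefore expected to give 4500 nM, with a range from 2000 nM to 10000 nM. The expected step is a 1.4-fold higher number from compound 2 to compound 3 (0.16 log units; within the scatter).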

Compound 3, concentration for total growth inhibition: 3390 nM
Compound 3: the middle estimate sits 1.3-fold (0.12 log units) above what was measured; low and high end bracket the measured number.
By their numbers in this assay, from the lowest: compounds 2, 3 and 1 (each within the scatter of the next, the first and the last beyond it).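

Losing the chlorine and moving a ring nitrogen changes little in this assay: pyrimidin-2-yl in place of 6-chloropyridazin-3-yl on the sulfonamide nitrogen gives a 1.1-fold higher number from compound 2 to compound 3 (0.03 log units; within the scatter). Within the data shown here, replacing 1,3-thiazol-2-yl with pyrimidin-2-yl gives a 1.9-fold lower number from compound 1 to compound 3 (0.28 log units; within the scatter), so this swap, unlike the one leading to compound 2, stays inside the usual scatter. No measurement here explains why these rings give such similar numbers. As far as these compounds go, whether this nitrogen needs a ring containing nitrogen at all remains open, and a plain phenyl ring or a methyl group there could answer that.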